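Methyl on the amide-bearing aryl ring: phenyl and pyridyl

The source may hold more compounds than are shown below. What is called first, only, known or untested is meant among the compounds shown, and "the series" means these compounds.

Compound 1 `O=C(NCCCCc1ccccc1)c1cccc(C2SCC(=O)N2c2ccccc2)c1` and compound 2 `Cc1cccc(N2C(=O)CSC2c2cccc(C(=O)NCCCCc3ccccc3)c2)c1` share one core. In a functional assay on HOS-TE85 cells (Homo sapiens) for inhibition, read by CCK-8 assay, with a stated time of 72 h (on this read-out lower numbers stand for stronger inhibition and higher numbers for weaker inhibition), compound 1 gives 15.9 nM and compound 2 gives 93.2 nM. The change between them is methyl in place of hydrogen on an aromatic carbon and the step it made is a 5.9-fold higher number from compound 1 to compound 2 (0.77 log units; beyond the scatter). Compound 3 `O=C(NCCCCn1cccn1)c1cccc(C2SCC(=O)N2c2ccccn2)c1` carries a different core; the difference between the two cores is not broken down here. In this assay compound 3 gives 60.3 nM; this number and that of compound 2 lie within the usual scatter of each other, while compound 1 gives a lower number beyond the scatter.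

Compound 4 `Cc1ccnc(N2C(=O)CSC2c2cccc(C(=O)NCCCCn3cccn3)c2)c1` has not been measured. It differs from compound 3 by methyl in place of hydrogen on an aromatic carbon. The two places are not word for word the same: in compound 2 the methyl sits on a six-membered aromatic ring of carbon only, meta to a large group; in compound 4 it sits on a six-membered aromatic ring with 1 nitrogen, meta to a large group and opposite the ring nitrogen. The change is therefore the same kind of change, not the same one.

In this assay, among the compounds with values here, the step expected here is a 4.1-fold higher number from compound 3 to compound 4 (0.62 log units; beyond the scatter), matched in direction and roughly in size to a 5.9-fold higher number from compound 1 to compound 2 (0.77 log units; beyond the scatter), on which it rests as the only measured instance of this kind of change. Compound 4 is expected to give about 250 nM in this assay. For compound 4 the expected range runs from 90 nM to 700 nM.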

Compound 4, half-maximal inhibitory concentration in the HOS-TE85 assay: 19.6 nM
Estimate against measurement, compound 4: 13-fold (1.11 log units) above, and the stated range ends above it.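

In the HOS-TE85 assay compound 4 gives 19.6 nM, and going from pyridin-2-yl to 4-methylpyridin-2-yl gives a 3.1-fold lower number from compound 3 to compound 4 (0.49 log units; beyond the scatter), whereas methyl in place of hydrogen on the ring of carbon only gives a 5.9-fold higher number from compound 1 to compound 2 (0.77 log units; beyond the scatter), so the same kind of change runs in opposite directions on the two cores. Set side by side, the two steps differ clearly: the same change on two cores in the HOS-TE85 assay, a 5.9-fold higher number (0.77 log units; beyond the scatter) from compound 1 to compound 2 and a 3.1-fold lower number (0.49 log units; beyond the scatter) from compound 3 to compound 4, 18-fold (1.26 log units) apart, beyond the scatter of two such steps In a physicochemical assay for solubility, read by turbidimetry, measured as kinetic solubility, at pH 6.8 (on this read-out lower numbers stand for lower solubility and higher numbers for higher solubility), compound 3 gives 50000 nM and compound 4 gives 50000 nM, which is no change at the digits printed from compound 3 to compound 4 (within the scatter).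

This shows that, in this series, neither the direction nor the size of the methyl step can be carried from one core to the other, but it does not show which structural difference reverses it, since the cores differ in more than one place, the methyl sits on a ring of carbon only in one pair and on a ring with 1 nitrogen in the other, and each step rests on a single pair.

From the compounds shown here alone, it remains open whether the reversal follows the ring that bears the methyl or another part of the core, a question that pairs differing only in one of these parts could separate. Going by these compounds, it also remains open whether a chlorine, a methoxy group, an amine or a carboxylic acid at the same place would follow the direction seen on either core.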